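Swapping the pendant phenyl substituent on a shared core

The source may hold more compounds than are shown below. What is called first, only, known or untested is meant among the compounds shown, and "the series" means these compounds.

Measured so far:
- compound 1, `c1ccc(-c2cn3ccnc3c(-c3ccc4ncn(C5CCCCC5)c4c3)n2)cc1`: 55.2%
- compound 2, `O=Cc1ccc(-c2cn3ccnc3c(-c3ccc4ncn(C5CCCCC5)c4c3)n2)cc1`: 82.2%
- compound 3, `Clc1ccc(-c2cn3ccnc3c(-c3ccc4ncn(C5CCCCC5)c4c3)n2)cc1`: 36.1%

Three compounds share one core and differ only in the group on the pendant phenyl ring. In a functional assay on UO-31 cells (Homo sapiens) for inhibition, read by sulforhodamine B assay, with a stated time of 48 h, tested at 10 uM (a higher number here means more inhibition at the concentration tested (going by the name of the read-out), a lower number less inhibition), compound 1 gives 55.2%, compound 2 gives 82.2% and compound 3 gives 36.1%. Compound 3 stands lowest of the three: a number 19.1 percentage points lower from compound 1 to compound 3 (beyond the scatter), and a number 46.1 percentage points lower from compound 2 to compound 3 (beyond the scatter).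

The next compound, compound 4 with `COc1ccccc1-c1cn2ccnc2c(-c2ccc3ncn(C4CCCCC4)c3c2)n1`, has not yet been measured. The change from compound 3 is 2-methoxyphenyl in place of 4-chlorophenyl on an aromatic carbon. Among the compounds with values here, two measured steps bear on this. Going from compound 1 to compound 3 added a chloro group, and a number 19.1 percentage points lower from compound 1 to compound 3 (beyond the scatter); compound 4 removes that chloro again, which on its own points back upward. Going from compound 1 to compound 2 added a group with an acceptor, and a number 27 percentage points higher from compound 1 to compound 2 (beyond the scatter); compound 4 also brings in an acceptor, but as a methoxy group, and in a different ring position, for which no measured step exists. A rise of a modest size is therefore expected for a number 18.9 percentage points higher from compound 3 to compound 4 (beyond the scatter). For compound 4 the estimated value in this assay is 55%, with a range from 35% to 75%.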

Compound 4, a percentage reported as inhibition, at one concentration (the size of the read-out at that concentration, not a potency): 24%
The estimate for compound 4 lay 31 percentage points above the measured number; the measured number lies below the stated range.
By their numbers in this assay, from the lowest: compound 4; then compound 3; then compound 1; then compound 2.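

Compound 4 stands lowest of the four in this assay. The step from the unsubstituted phenyl is large (a number 31.2 percentage points lower from compound 1 to compound 4 (beyond the scatter)), the step from the formyl compound is larger still (a number 58.2 percentage points lower from compound 2 to compound 4 (beyond the scatter)), and even the chloro compound, until now the lowest, reads higher (a number 12.1 percentage points lower from compound 3 to compound 4 (beyond the scatter)). This shows that losing the chloro group does not bring the number back, and that a group with a hydrogen-bond acceptor on the pendant phenyl ring does not by itself give a high number, as 2-methoxyphenyl carries one and still reads lowest. Nothing measured here accounts for this fall.

The compounds shown leave open whether the drop belongs to the methoxy group itself or to where it sits on the phenyl ring, as 2-methoxyphenyl and 4-chlorophenyl differ in both the group and its ring position. Also open, from the compounds shown here alone, is how an amine or a carboxylic acid on the same ring would read, and whether any group other than the formyl of compound 2 lifts the number above that of compound 1.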